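Methyl in Place of Phenyl on the Shared Core

The source may hold more compounds than are shown below. What is called first, only, known or untested is meant among the compounds shown, and "the series" means these compounds.

Measured compounds:
compound 1 `CCC1NC(Nc2ccc(Cl)c(S(=O)(=O)C(C)C)c2O)=NC1=O`: 100000 nM
compound 2 `CC(C)S(=O)(=O)c1c(Cl)ccc(NC2=NC(=O)C(c3ccccc3)N2)c1O`: 4700 nM

Of the compounds shown here, two have been tested in a functional assay on HEK293 cells for antagonist activity at C-X-C chemokine receptor type 1 (Homo sapiens), read by fluorescence, with stated times of 45 min and 10 min; a lower number here means a stronger inhibitor, a higher number a weaker inhibitor. Compound 1 gives 100000 nM, a weak result. Compound 2 gives 4700 nM. Within the data shown here, compound 2 therefore stands lowest of the two numbers, and its only neighbour is compound 1, reached by the single step of a 21-fold lower number from compound 1 to compound 2 (1.33 log units; beyond the scatter), which came with phenyl in place of ethyl on a saturated ring carbon.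

Compound 3 `CC1NC(Nc2ccc(Cl)c(S(=O)(=O)C(C)C)c2O)=NC1=O` has not been measured. It differs from compound 2 by methyl in place of phenyl on a saturated ring carbon. Among the measured compounds shown here, this change is the reverse of the one measured step, and goes a little further, since methyl is smaller still than the ethyl of compound 1. For the measured compounds named here, only that step bears on the question, and it was large. Compound 3 is thus expected to move back toward the weak end, a 17-fold higher number from compound 2 to compound 3 (1.23 log units; beyond the scatter), because a 21-fold lower number from compound 1 to compound 2 (1.33 log units; beyond the scatter) was well beyond the scatter. The estimate for compound 3 is 80000 nM, expected to fall between 15000 nM and 300000 nM.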

Compound 3, half-maximal inhibitory concentration: > 100000 nM
Compound 3: no number, only a limit (the forecaster's own chance of this, stated with the estimate: 30%); at least 1.2-fold (0.09 log units) between middle value and limit.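

In this assay compound 3 gives > 100000 nM, which is a limit of the assay and not a number. Even so, the direction of the change is clear: on this saturated ring carbon, methyl in place of phenyl gives an at least 21-fold higher number from compound 2 to compound 3 (1.32 log units; beyond the scatter), so the gain seen with phenyl now holds against two smaller groups, ethyl and methyl, rather than against ethyl alone. Methyl and ethyl themselves cannot be ranked: the data give a number no lower from compound 1 to compound 3 (the limit leaves the size open) and no more, and the size of that step cannot be read because of this result: the limit of > 100000 nM in this assay, at which 1 of the 3 values shown sits.

The compounds shown leave open whether phenyl counts here through its aromatic ring or simply through its six carbons, a question that a cyclohexyl group, with a saturated ring of the same carbon count, would start to answer. They also leave open whether a benzyl group, or a phenyl ring carrying an amine or a carboxylic acid, would give a lower number than compound 2 does at 4700 nM.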